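The source may hold more compounds than are shown below. What is called first, only, known or untested is meant among the compounds shown, and "the series" means these compounds.

Among the measured compounds shown here, compound 2 `COc1cc2ncnc(N3CCCc4ccccc43)c2cc1NC(=O)/C=C/C(C)C` gives 4290 nM in a functional assay on MCF7 cells (Homo sapiens) for antiproliferative activity, read by MTT assay, with a stated time of 72 h (on this read-out higher numbers stand for weaker inhibition and lower numbers for stronger inhibition), the lowest of the two numbers so far, though its only neighbour, compound 1 `COc1cc2ncnc(N3CCc4ccccc43)c2cc1NC(=O)/C=C/C(C)C`, gives 6780 nM, and the step of a 1.6-fold lower number from compound 1 to compound 2 (0.20 log units; within the scatter) stays within the scatter. Compound 3 `COc1cc2ncnc(N3CCCc4ccccc43)c2cc1NC(=O)/C=C/CN1CCN(C)CC1` differs from compound 2 by (4-methylpiperazin-1-yl)methyl in place of isopropyl on a double-bonded chain carbon bound to a double-bonded chain carbon, a change on the double-bonded chain rather than on the aromatic carbon where compound 1 and compound 2 differ. For the measured compounds named here, no measured step touches the chain end, so nothing among the measured compounds bears directly on this change, and the single measured step is within the scatter. The step to compound 3 in this assay is therefore expected to be modest and uncertain in direction, estimated as a 1.4-fold lower number from compound 2 to compound 3 (0.16 log units; within the scatter). For compound 3 the number in this assay is estimated at 3000 nM, with a range from 800 nM to 12000 nM.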

Compound 3, half-maximal inhibitory concentration: 8560 nM
Compound 3: the middle estimate sits 2.9-fold (0.46 log units) below what was measured; the measured number falls inside the stated range.
By their numbers in this assay, from the lowest: compounds 2, 1 and 3 (each within the scatter of the next).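

In this assay, among the compounds shown here, the first measured change at the chain end gives a 2.0-fold higher number from compound 2 to compound 3 (0.30 log units; within the scatter). At this double-bonded chain carbon, then, an isopropyl group with no ring and a (4-methylpiperazin-1-yl)methyl group, which has more heavy atoms, a six-membered non-aromatic ring and two nitrogens, give numbers that lie within the scatter of each other, so this pair shows no measurable effect of the change. Nothing available accounts for this result or gives any property of either group as measured.

As far as these compounds go, whether a dimethylamino group, a morpholin-4-ylmethyl group or a longer chain at the same carbon would move the number beyond the scatter remains open. Also open, from the compounds shown here alone, is whether the (4-methylpiperazin-1-yl)methyl group would give a similar step with 2,3-dihydro-1H-indol-1-yl on the aromatic carbon.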